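The source may report more compounds than this note shows. Statements on the series, on what has been measured and on what is new or still open speak of the compounds shown alone.

Values in a functional assay on HeLa cells (Homo sapiens) for antiproliferative activity, read by MTT assay, with a stated time of 72 h; on this read-out higher numbers stand for weaker inhibition and lower numbers for stronger inhibition:
- compound 1 `COc1ccc(-c2ncnn2-c2cc(OC)c(OC)c(OC)c2)cc1`: 280 nM
- compound 2 `COc1cccc(-c2ncnn2-c2cc(OC)c(OC)c(OC)c2)c1`: > 10000 nM (a limit, not a number)
- compound 3 `COc1cc(-n2ncnc2-c2ccc(Cl)c(Cl)c2)cc(OC)c1OC`: > 10000 nM (a limit, not a number)

Compound 2 has no exact number in this assay. Compound 2 gives only a limit, > 10000 nM. Among the compounds with values here, this is the limit of > 10000 nM in this assay, at which 2 of the 3 values shown sit, so compound 1 is the only compound here with a true number.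

The next compound is compound 4 `CCOc1cccc(-c2ncnn2-c2cc(OC)c(OC)c(OC)c2)c1`. Its difference from compound 2 is small: methyl in place of hydrogen on a saturated chain carbon bound to an oxygen on an aromatic ring. In plain terms, methoxy becomes ethoxy.

Within the data shown here, no measured step makes this same change, so the evidence is indirect. The closest comparison is an at least 35-fold higher number from compound 1 to compound 2 (1.55 log units; beyond the scatter), a large loss when 3-methoxyphenyl replaces 4-methoxyphenyl. The change an at least 35-fold higher number from compound 1 to compound 3 (1.55 log units; beyond the scatter) is just as large, so neither replacement of 4-methoxyphenyl kept a measurable value. The comparison a step that the two limits leave unreadable from compound 2 to compound 3 adds nothing about size.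

Compound 4 keeps the arrangement of compound 2 and only lengthens methoxy to ethoxy, so no change beyond the scatter is expected. The estimated step is a step that the limit leaves unreadable from compound 2 to compound 4. For compound 4 the expected value is 12000 nM, with an estimated range from 3000 nM to 30000 nM.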

Compound 4, half-maximal inhibitory concentration: > 10000 nM
Compound 4 ended at the assay's limit; the forecaster's own chance of this, stated with the estimate: 75%; the middle value lies beyond the limit too.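

In this assay, within the data shown here, compound 2 and compound 4 both stop at a limit of the assay instead of giving a true number, so no step between them can be read: the limit of > 10000 nM in this assay, at which 3 of the 4 values shown sit.

The compounds shown leave open whether ethoxy in place of methoxy changes the activity of compound 2 at all.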